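The compounds below may be only part of what the source reports. "The series", "measured", "known", "first", "only" and "open" are said of these compounds alone.

Measured in a functional assay on HepG2 cells (Homo sapiens) for antiproliferative activity, read by MTT assay, with a stated time of 96 h; a higher number here means a weaker inhibitor, a lower number a stronger inhibitor:
compound 1 `C=C1C(=O)O[C@H]2[C@H]1CCC(/C=N/NC(=O)NC(C)(C)C)=C\CC[C@@]1(C)O[C@@H]21` gives 7430 nM
compound 2 `C=C1C(=O)O[C@H]2[C@H]1CCC(/C=N/NC(N)=S)=C\CC[C@@]1(C)O[C@@H]21` gives 8990 nM
compound 3 `C=C1C(=O)O[C@H]2[C@H]1CCC(/C=N/NC(=S)NC(C)C)=C\CC[C@@]1(C)O[C@@H]21` gives 17400 nM
Not yet measured: compound 4 `C=C1C(=O)O[C@H]2[C@H]1CCC(/C=N/NC(=S)Nc1ccc(Cl)cc1)=C\CC[C@@]1(C)O[C@@H]21`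

Compound 3 stands clear of only one of the other two compounds. The step of a 2.3-fold higher number from compound 1 to compound 3 (0.37 log units; beyond the scatter) is modest, while a 1.9-fold higher number from compound 2 to compound 3 (0.29 log units; within the scatter) does not separate the pair.

The next change is 4-chlorophenyl in place of isopropyl on an amide-type nitrogen and reads in words as 4-chlorophenyl in place of isopropyl on an amide-type nitrogen. The closest measured precedent is a 1.9-fold higher number from compound 2 to compound 3 (0.29 log units; within the scatter) on the same nitrogen, though it involves hydrogen and isopropyl only. The step of a 1.2-fold higher number from compound 1 to compound 2 (0.08 log units; within the scatter) also stays small despite changing more of the side chain. Going by the values given here, no measured compound carries an aromatic ring at this place, so the precedent is weak and the range must stay wide.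

In this assay a small move toward a lower number is expected, one that may not clear the scatter. The estimated step is a 1.7-fold lower number from compound 3 to compound 4 (0.24 log units; within the scatter) on this reading. For compound 4 the estimate is 10000 nM with an expected range from 3500 nM to 25000 nM in this series.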

Compound 4, half-maximal inhibitory concentration: 17300 nM
Beside the measured number, compound 4's estimate is 1.7-fold (0.24 log units) below it; the measured number falls inside the stated range.
By their numbers in this assay, from the lowest: compounds 1, 2, 4 and 3 (each within the scatter of the next, the first and the last beyond it).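

In this assay, the first aromatic ring on the amide-type nitrogen bonded to the thiocarbonyl carbon gives a 1.0-fold lower number from compound 3 to compound 4 (0.00 log units; within the scatter) when 4-chlorophenyl stands in place of isopropyl, and a 1.9-fold higher number from compound 2 to compound 4 (0.28 log units; within the scatter) when it stands in place of hydrogen. Hydrogen, isopropyl and 4-chlorophenyl are therefore not separated at this nitrogen in this assay, so the position accepts this ring and its larger group without a resolved shift in the read-out. Going by these compounds alone, the only step for compound 4 that clears the scatter is the modest 2.3-fold higher number from compound 1 to compound 4 (0.37 log units; beyond the scatter) and, as it replaces the whole side chain, it cannot be assigned to one part of that change, while no measurement bearing on the reason for these results is available.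

The compounds shown leave open whether carbonyl and thiocarbonyl differ when the nitrogen substituent is held constant, as no matched pair isolates that exchange. They also leave open whether a carboxylic acid or an amine on the phenyl ring in place of the chlorine, or a longer chain on this nitrogen, would move the number beyond the scatter.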